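The compounds below may be only part of what the source reports. "The series", "measured", "known", "first", "only" and "open" are said of these compounds alone.

Compound 1 `Clc1cccc(-n2ncnc2NCc2ccccc2)c1Cl`: 209 nM
Compound 2 `COc1ccccc1CNc1ncnn1-c1cccc(Cl)c1Cl`: 708 nM
Compound 3 `CCOc1ccccc1CNc1ncnn1-c1cccc(Cl)c1Cl`: 490 nM

In a functional assay for antagonist activity at P2X purinoceptor 7 (Rattus norvegicus), read by FLIPR and calcium flux (a higher number here means a weaker inhibitor, a lower number a stronger inhibitor), compound 3 gives 490 nM, the second highest of the three numbers: a 1.4-fold lower number from compound 2 to compound 3 (0.16 log units; within the scatter), whereas a 2.3-fold higher number from compound 1 to compound 3 (0.37 log units; beyond the scatter). Compound 4 `CS(=O)(=O)c1ccccc1CNc1ncnn1-c1cccc(Cl)c1Cl` differs from compound 3 by methylsulfonyl in place of ethoxy on an aromatic carbon. Going by the values given here, three measured steps bear on it. Both substitutions at this carbon raised the number modestly, a 3.4-fold higher number from compound 1 to compound 2 (0.53 log units; beyond the scatter) and a 2.3-fold higher number from compound 1 to compound 3 (0.37 log units; beyond the scatter), while the swap between the two alkoxy groups stayed within scatter, a 1.4-fold lower number from compound 2 to compound 3 (0.16 log units; within the scatter). Among the compounds with values here, no measured step introduces a methylsulfonyl group, so the new group remains untested. Compound 4 is therefore expected to land near compound 3 or somewhat higher, a 1.6-fold higher number from compound 3 to compound 4 (0.21 log units; within the scatter). Compound 4 is estimated at 800 nM, with a range from 250 nM to 2500 nM in this assay.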

Compound 4, half-maximal inhibitory concentration: 39.8 nM
Beside the measured number, compound 4's estimate is 20-fold (1.30 log units) above it, and the stated range ends above it.
By their numbers in this assay, from the lowest: compound 4; then compound 1; then compounds 3 and 2 (each within the scatter of the next).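

In this assay, this carbon, ortho to a large group, proves not to be a place where every substituent weakens inhibition: methylsulfonyl in place of hydrogen gives a 5.3-fold lower number from compound 1 to compound 4 (0.72 log units; beyond the scatter) and so reverses the direction seen with both alkoxy groups. The replacement of the alkoxy groups is far larger than the swap between them (a 12-fold lower number from compound 3 to compound 4 (1.09 log units; beyond the scatter) and an 18-fold lower number from compound 2 to compound 4 (1.25 log units; beyond the scatter)), so the identity of the group here matters greatly. Nothing available explains this difference. On these data alone, it remains open whether a sulfonamide, an amide or a nitrile at this carbon would match methylsulfonyl, and whether methylsulfonyl would have the same effect elsewhere on the ring.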